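The source may hold more compounds than are shown below. What is called first, only, known or untested is meant among the compounds shown, and "the series" means these compounds.

Measured in a functional assay on HEK293 cells (Homo sapiens) for cytotoxicity; a higher number here means that more compound is tolerated, a lower number that less compound is tolerated:
Compound 1 `COc1ccc([C@H]2CC(=O)N(c3cccc(N(C)C)c3)C2)cc1OC1CCCC1`: > 10000 nM
Compound 2 `COc1ccc([C@H]2CC(=O)N(c3cccc(C#N)c3)C2)cc1OC1CCCC1`: > 10000 nM
Compound 3 `COc1ccc([C@H]2CC(=O)N(c3ccccc3C(F)(F)F)C2)cc1OC1CCCC1`: > 10000 nM

Each of these entries is a limit of the assay and not a number. Compound 3 is therefore known only through its limit, > 10000 nM. It has no position of its own among the three, as all of them share one mark: the limit of > 10000 nM in this assay, at which 3 of the 3 values shown sit.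

Compound 4 `COc1ccc([C@H]2CC(=O)N(c3ccc([S+](C)[O-])cc3)C2)cc1OC1CCCC1` keeps the shared core and differs from compound 3 in the group on the amide-type nitrogen in a ring: a group of 9 heavy atoms (7 carbon, 1 oxygen, 1 sulfur; one six-membered aromatic ring of carbon only) in place of a group of 10 heavy atoms (7 carbon, 3 fluorine; one six-membered aromatic ring of carbon only), on an amide-type nitrogen in a ring. The entering group has no common name.

Within the data shown here, three measured steps bear on this change, as each alters the aromatic group on that same nitrogen: a step that the two limits leave unreadable from compound 1 to compound 2, a step that the two limits leave unreadable from compound 1 to compound 3 and a step that the two limits leave unreadable from compound 2 to compound 3. None of them has a readable size, so they offer no measured effect to carry over. No readable step is expected in this assay, in either direction. This expectation starts from compound 3, whose reading is the limit > 10000 nM.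

The estimate for compound 4 is 20000 nM, with an expected range from 8000 nM to 60000 nM. The estimated change is a step that the limit leaves unreadable from compound 3 to compound 4, and a limit is the most likely report.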

Compound 4, half-maximal cytotoxic concentration: 7510 nM
For compound 4 the middle estimate is 2.7-fold (0.43 log units) above the measured one; measured number below the stated range.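

In this assay compound 4 is the only compound shown with a number and not a limit, so a change to the aromatic group on the amide-type nitrogen alone can bring a reading within the range of the assay. The steps among compound 1, compound 2 and compound 3 cannot be read, as all three stop at the same limit of the assay: the limit of > 10000 nM in this assay, at which 3 of the 4 values shown sit.

On these data alone, compound 4 does give readable steps, namely an at least 1.3-fold lower number from compound 3 to compound 4 (0.12 log units; that floor lies within the scatter), an at least 1.3-fold lower number from compound 2 to compound 4 (0.12 log units; that floor lies within the scatter) and an at least 1.3-fold lower number from compound 1 to compound 4 (0.12 log units; that floor lies within the scatter), but each of these is only a floor, so the true size of each change remains unknown and may be small or large.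

The compounds shown leave open whether the group holding sulfur and oxygen would give a similar number if it sat elsewhere on the aromatic ring, and how much of the reading depends on that oxygen. They also leave open how this assay would read for the same aromatic ring carrying a carboxylic acid, a primary amine or a sulfone.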